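The compounds below may be only part of what the source reports. "The series", "measured", "known", "first", "only" and "open" are said of these compounds alone.

Measured so far in an ADME assay on Raji cells (Homo sapiens) for cytotoxicity, read by CellTiter-Glo and resazurin assay, with a stated time of 72 h; a lower number here means that less compound is needed, a higher number that more compound is needed for the effect:
compound 1 `CCOC(=O)CCCCCOc1cccc(CN(C(=O)c2ccc(-c3cccc(OCC(C)C)c3)cc2)C(C)C)c1` gives a limit, > 26000 nM
compound 2 `CCOC(=O)CCCCCOc1cccc(CN(C(=O)c2ccc(-c3cccc(O)c3)cc2)C(C)C)c1` gives a limit, > 26000 nM
compound 3 `CCOC(=O)CCCCCOc1cccc(CN(C(=O)c2ccc(-c3cccc(F)c3)cc2)C(C)C)c1` gives a limit, > 26000 nM

Compound 3 therefore stands at a limit and not at a number in this assay, and the two other values sit in the same place: all three are the limit of > 26000 nM in this assay, at which 3 of the 3 values shown sit. The measured steps carry no readable size: a step that the two limits leave unreadable from compound 1 to compound 2, a step that the two limits leave unreadable from compound 1 to compound 3 and a step that the two limits leave unreadable from compound 2 to compound 3 all run between limits, so none of them gives a direction or a magnitude.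

Compound 4 `CCOC(=O)CCCCCOc1cccc(CN(C(=O)c2ccc(Br)cc2)C(C)C)c1` differs from compound 3 by bromo in place of 3-fluorophenyl on an aromatic carbon. No measured step touches this part of the shared core, so nothing among the numbers shown bears on it directly; all that is known is that every measured compound remains at the limit.

For compound 4 in this assay a value of 26000 nM is expected, within 13000 nM to 60000 nM, most probably reported again as a limit. The expected step, a number no higher from compound 3 to compound 4 (the limit leaves the size open), is estimated as none beyond the scatter.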

Compound 4, half-maximal effective concentration: > 26000 nM
Compound 4: no number, only a limit (the forecaster's own chance of this, stated with the estimate: 85%); the middle value lies on the limit itself.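

Compound 4 joins compound 1, compound 2 and compound 3 at a limit in this assay, so no step among these compounds can be read: the limit of > 26000 nM in this assay, at which 4 of the 4 values shown sit. The compounds shown leave open at what concentration any of them reaches the half-maximal effect, and whether any of these changes alters it.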